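The source may report more compounds than this note shows. Statements on the series, on what has been measured and on what is new or still open speak of the compounds shown alone.

Measured in a functional assay on MDA-MB-231 cells (Homo sapiens) for cytotoxicity, read by MTT assay; on this read-out higher numbers stand for weaker inhibition and lower numbers for stronger inhibition:
Compound 1 `c1ccc(Cc2nnc(-c3c[nH]c4ccccc34)o2)cc1` gives > 1000000 nM, a limit of the assay.
Compound 2 `COc1ccc(-c2nnc(-c3c[nH]c4ccccc34)o2)cc1` gives > 1000000 nM, a limit of the assay.
Compound 3 `COc1cc(-c2nnc(-c3cn(C)c4ccccc34)o2)ccc1OCc1ccccc1` gives > 1000000 nM, a limit of the assay.

Compound 1 thus stands only at a limit in this assay, and the two further values shown are limits as well: the limit of > 1000000 nM in this assay, at which 3 of the 3 values shown sit. Among the compounds with values here, no pair of measured compounds differing in a single place is available, so nothing measured tells how one change on the shared core moves this read-out.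

Compound 4 `FC(F)(F)c1nnc(-c2c[nH]c3ccccc23)o1` differs from compound 1 by trifluoromethyl in place of benzyl on an aromatic carbon. With every value shown sitting at the limit (the limit of > 1000000 nM in this assay, at which 3 of the 3 values shown sit), no direction can be read from the data; the expected step of a number no higher from compound 1 to compound 4 (the limit leaves the size open) is therefore none beyond the scatter, with the compound most likely reported as a limit again. Compound 4 is expected at 1000000 nM, with a range of 200000 nM to 5000000 nM.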

Compound 4, half-maximal inhibitory concentration: > 1000000 nM
Compound 4 ended at the assay's limit (the forecaster's own chance of this, stated with the estimate: 85%); the middle value lies on the limit itself.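

No step can be read between compound 1 and compound 4, trifluoromethyl in place of benzyl, because both stand at a limit: the limit of > 1000000 nM in this assay, at which 4 of the 4 values shown sit.

The compounds shown leave open which change on the shared core, if any, would give a measurable value on this read-out.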